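This account rests on a few compounds, and the source may have more. Where it says the series, first, only, none or still open, it means among the compounds named here.

Measured so far in a functional assay (aorta) with Rattus norvegicus as the target; a higher number here means a weaker inhibitor, a lower number a stronger inhibitor:
Compound 1, `CCO/C(O)=C1\C(COCCNc2n[nH]c(N)n2)=NC(C)=C(C(=O)OC)C1c1cccc(C(F)(F)F)c1Cl`, gives 3.98 nM.
Compound 2, `CCO/C(O)=C1\C(COCCNc2n[nH]c(O)n2)=NC(C)=C(C(=O)OC)C1c1cccc(Cl)c1Cl`, gives 10 nM.

Compound 2 stands at the higher of the two numbers, and its gap to compound 1 lies beyond the usual scatter of repeat measurements, so of these two compound 2 is the weaker inhibitor in this assay. Compound 1 and compound 2 differ in more than one place, so the two values alone do not say which change carries that gap.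

Compound 3, `CCO/C(O)=C1\C(COCCNc2nccnc2Cl)=NC(C)=C(C(=O)OC)C1c1cccc(Cl)c1Cl`, is not yet measured. It differs from compound 2 in a single place, on the amine nitrogen at the end of the chain: 3-chloropyrazin-2-yl in place of 5-hydroxy-1H-1,2,4-triazol-3-yl on an amine nitrogen. For the measured compounds named here, no pair among the measured compounds isolates this exchange, so no measured step points the way. With nothing to lean on, the step from compound 2 to compound 3 in this assay is expected to be no change at the digits printed from compound 2 to compound 3 (within the scatter), that is, no change clearly beyond the scatter, with wide uncertainty in either direction. Compound 3 is therefore estimated at 10 nM in this assay, within a range of 3 nM to 40 nM.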

Compound 3, half-maximal inhibitory concentration: 2.51 nM
The estimate for compound 3 lay 4.0-fold (0.60 log units) above the measured number; measured number below the stated range.
By their numbers in this assay, from the lowest: compounds 3 and 1 (each within the scatter of the next); then compound 2.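

In this assay, 3-chloropyrazin-2-yl in place of 5-hydroxy-1H-1,2,4-triazol-3-yl on the amine nitrogen gives a 4.0-fold lower number from compound 2 to compound 3 (0.60 log units; beyond the scatter), the only step shown that isolates a change at this position. The amine nitrogen at the end of the chain therefore accepts a six-membered aromatic ring with 2 hetero atoms, a chlorine and 0 hydrogen-bond donors in place of a five-membered aromatic ring with 3 hetero atoms and 2 hydrogen-bond donors, and this pair shows that the donors of the leaving group are not required for the lower number. No measurement available here bears on the reason for this step, which rests on a single pair.

The exchange alters ring size, hetero atoms, donors and chlorine at once, so the part that carries the step remains unassigned; unsubstituted pyrazin-2-yl and 3-methoxypyrazin-2-yl on the same amine nitrogen would help to separate these features. Also open, going by these compounds, is whether the same exchange gives a step of similar size on the core of compound 1, which carries a trifluoromethyl group.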